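Pyrazoline amides: thiazolyl to methyl on the carbonyl

A few compounds are considered here, and "the series" means these few. Any claim that something is new, unique, unknown or untested is made for them only; others in the source may bear on it.

Measured compounds:
- compound 1, `C[C@@H]1C=NN(C(=O)C(C)(C)C)[C@@H]1c1ccccc1`: 6.5
- compound 2, `O=C(c1cscn1)N1CCC(C(=O)N2N=CC[C@H]2c2ccccc2)CC1`: 3
- compound 3, `CC(C)(C)C(=O)n1nccc1-c1ccccc1`: 8.3

In a physicochemical assay for lipophilicity, read by HPLC, measured as chromatographic lipophilicity, at pH 7.4 (on this read-out higher numbers stand for higher lipophilicity and lower numbers for lower lipophilicity), compound 2 gives 3, the lowest of the three numbers. The nearest of the other two is compound 1, which in this assay gives 6.5, a gap that lies beyond the scatter. The furthest is compound 3, which in this assay gives 8.3, again beyond the scatter. None of the three pairs differ in one place only, so what they show is simply the spread of values, not a step that can be read off.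

The compound to be measured next is compound 4, `CC(=O)N1CCC(C(=O)N2N=CC[C@H]2c2ccccc2)CC1`. It differs from compound 2 in one place:

methyl in place of 1,3-thiazol-4-yl on a carbonyl carbon

Among the measured compounds shown here, no measured pair in this set carries the same change, so the expectation rests on compound 2 alone. For the step from compound 2 to compound 4 in this assay the estimate is a downward move of modest size, a number 0.70 log units lower from compound 2 to compound 4 (beyond the scatter), beyond the scatter. Compound 4 is therefore estimated to give 2.3 in this assay, with a range from 1.7 to 2.9.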

Compound 4, distribution coefficient: 2.5
Compound 4: middle estimate off by 0.20 log units, on the low side, and the stated range covers the measured number.
By their numbers in this assay, from the lowest: compound 4; then compound 2; then compound 1; then compound 3.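

In this assay, among the compounds shown here, the change from 1,3-thiazol-4-yl to methyl on a carbonyl carbon whose other neighbours are an amide-type nitrogen in a ring gives a number 0.50 log units lower from compound 2 to compound 4 (beyond the scatter), and this is the first step that can be read at a single place rather than inferred from a spread of values. It shows that at this position, removing the five-membered aromatic ring and leaving a single carbon moves the read-out down, with the rest of the structure held constant. As this is one pair in one direction, it fixes the sign and size of this change on this core only and supports no wider pattern, and no measurement at hand accounts for the step.

Still open, going by these compounds, is how the read-out responds on the same carbonyl carbon to a longer chain such as n-butyl, to a phenyl ring, or to a dimethylamino group, each of which would show whether the values follow the size of the group or its kind. Also open, on these data alone, is whether the same change from 1,3-thiazol-4-yl to methyl gives a similar step when the phenyl group of the shared core carries a chlorine or a methoxy group.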